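Series notes: chain variation at the ring nitrogen

The source may hold more compounds than are shown below. What is called first, only, known or untested is meant among the compounds shown, and "the series" means these compounds.

The shared core carries a propyl chain on one ring nitrogen and a variable chain on the other. Compound 1 `C=CCCn1c(=O)c2[nH]cnc2n(CCC)c1=O` gives 60 nM in an assay on Cerebral cortex for binding affinity to adenosine receptor A1 (Cavia porcellus), read by radioligand binding; on this read-out lower numbers stand for stronger inhibition and higher numbers for weaker inhibition. Compound 2 `CCCn1c(=O)n(CCOCC)c(=O)c2[nH]cnc21` gives 1900 nM in this assay; of the two numbers recorded so far, compound 2 stands highest, with the step of a 32-fold higher number from compound 1 to compound 2 (1.50 log units; beyond the scatter) describing the change from ethoxy in place of vinyl on a saturated chain carbon, two bonds along the chain from an aromatic nitrogen.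

Compound 3 `CCCn1c(=O)n(CC(C)=O)c(=O)c2[nH]cnc21` differs from compound 2 by acetyl in place of ethoxymethyl on a saturated chain carbon bound to an aromatic nitrogen. Among the compounds with values here, only the step from compound 1 to compound 2 bears on this change, and it shows that introducing an oxygen into the chain at this position cost a large amount of affinity. The new chain of compound 3 is shorter and again carries an oxygen, now as a carbonyl. The expectation is therefore a step of a 1.6-fold higher number from compound 2 to compound 3 (0.20 log units; within the scatter) in this assay, with no strong basis for a recovery toward compound 1. For compound 3 the estimate is 3000 nM, within a range from 800 nM to 12000 nM.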

Compound 3, inhibition constant: 11400 nM
Compound 3: middle estimate off by 3.8-fold (0.58 log units), on the low side; the measured number falls inside the stated range.
By their numbers in this assay, from the lowest: compound 1; then compound 2; then compound 3.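

The chain position does not treat its two oxygen-bearing chains alike: in this assay, the change from 2-ethoxyethyl to 2-oxopropyl gives a 6.0-fold higher number from compound 2 to compound 3 (0.78 log units; beyond the scatter), even though both the leaving and the entering group count one hydrogen-bond acceptor and no donors. Measured against the unsaturated chain of compound 1, the acetyl change gives a 190-fold higher number from compound 1 to compound 3 (2.28 log units; beyond the scatter), which exceeds the step to the ethoxy chain, a 32-fold higher number from compound 1 to compound 2 (1.50 log units; beyond the scatter), so the presence of an oxygen in the chain does not alone set the number at this position. Nothing at hand accounts for the difference between the ethoxymethyl and acetyl groups.

The three compounds leave open whether chain length or the form of the oxygen matters more, since the acetyl change alters both the heavy-atom count and the presence of a double bond. As far as these compounds go, how a hydroxyl, an amine or a carboxylic acid on the same chain, or a longer plain alkyl chain at this position, would read in this assay also remains open.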